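A few compounds are considered here, and "the series" means these few. Any claim that something is new, unique, unknown or untested is made for them only; others in the source may bear on it.

Of the compounds shown here, two built on the same core have been tested in a functional assay on A549 cells (Homo sapiens) for antiproliferative activity, read by MTT assay, with a stated time of 72 h; a higher number here means a weaker inhibitor, a lower number a stronger inhibitor. Compound 1 `CS(=O)(=O)c1ccc(C(=O)Nc2ccc(Cl)c(-c3nnc4c(Cl)cccn34)c2)c(Cl)c1` reaches only the limit > 100000 nM in this assay, a boundary of the measurement rather than a number, as the limit of > 100000 nM in this assay, at which 1 of the 2 values shown sits, records. Compound 2 `O=C(Nc1ccc(Cl)c(-c2nnc3c(Cl)cccn23)c1)c1cccc(Cl)c1` gives 52700 nM in this assay, and that is the only number shown. Compound 3 `Cc1cc(Cl)ccc1C(=O)Nc1ccc(Cl)c(-c2nnc3c(Cl)cccn23)c1` has not yet been measured. It differs from compound 2 in one place: 4-chloro-2-methylphenyl in place of 3-chlorophenyl on a carbonyl carbon. Within the data shown here, no measured pair of neighbouring compounds shows how such a swap moves this assay, so the change from compound 2 to compound 3 is expected to stay within the usual scatter, with no clear direction. On that basis compound 3 is estimated at 50000 nM in this assay, between 20000 nM and 150000 nM, which amounts to an expected step of a 1.1-fold lower number from compound 2 to compound 3 (0.02 log units; within the scatter).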

Compound 3, half-maximal inhibitory concentration: > 100000 nM
Compound 3: no number, only a limit; the forecaster's own chance of this, stated with the estimate: 30%; middle value at least 2.0-fold (0.30 log units) from the limit.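

In this assay compound 3 gives > 100000 nM, which is a limit and not a number. From the compounds shown here alone, the first step measured at this place on the carbonyl carbon is an at least 1.8-fold higher number from compound 2 to compound 3 (0.27 log units; that floor lies within the scatter), and its true size remains unknown, as only a floor can be read. Placing 4-chloro-2-methylphenyl here in place of 3-chlorophenyl therefore brings no lower number, and the set shown now sits mostly at the edge of what the measurement can report: the limit of > 100000 nM in this assay, at which 2 of the 3 values shown sit.

The compounds shown do not separate the added methyl from the changed chlorine position, so it remains open which part of the swap matters. They also leave open how a phenyl ring carrying an amine or a carboxylic acid would read at this place in this assay.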